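Substituent changes at one aromatic carbon: toward compound 4

The compounds below may be only part of what the source reports. "The series", "measured", "known", "first", "only" and "open" are said of these compounds alone.

Of the compounds shown here, three have been measured in an assay on cells for antagonist activity at transient receptor potential cation channel subfamily V member 1 (Homo sapiens), read by FLIPR and calcium flux, with a stated time of 6 min; a lower number here means a stronger inhibitor, a higher number a weaker inhibitor. Compound 1 `CCCN(CCC)c1nc(C(C)(C)C)ccc1CNC(=O)C(C)c1ccc(NS(C)(=O)=O)c(F)c1` gives 2.5 nM, compound 2 `CC(C(=O)NCc1ccc(C(C)(C)C)nc1N1CCCCCC1)c1ccc(NS(C)(=O)=O)c(F)c1` gives 0.9 nM and compound 3 `CC(C(=O)NCc1ccc(C(C)(C)C)nc1OC1CCCCC1)c1ccc(NS(C)(=O)=O)c(F)c1` gives 2.5 nM. Compound 2 holds the lowest number of the three, and both of its steps lie beyond the scatter: a 2.8-fold lower number from compound 1 to compound 2 (0.44 log units; beyond the scatter) and a 2.8-fold higher number from compound 2 to compound 3 (0.44 log units; beyond the scatter). Between the other two, no change at the digits printed from compound 1 to compound 3 (within the scatter).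

Compound 4 `CC(C(=O)NCc1ccc(C(C)(C)C)nc1SCCCN1CCCC1)c1ccc(NS(C)(=O)=O)c(F)c1` is unmeasured in this assay and differs from compound 2 at the same aromatic carbon that separates the measured compounds: (3-(pyrrolidin-1-yl)propyl)sulfanyl in place of azepan-1-yl on an aromatic carbon. The measured steps that bear on this position are the two involving compound 2, each modest in size. An increase of comparable size is expected for compound 4, because replacing azepan-1-yl in compound 2 gave a 2.8-fold higher number from compound 2 to compound 3 (0.44 log units; beyond the scatter) in the one measured case. Compound 4 is therefore expected near 3 nM, with a range of 1 nM to 10 nM. The expected step is a 3.3-fold higher number from compound 2 to compound 4 (0.52 log units; beyond the scatter).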

Compound 4, inhibition constant: 17.1 nM
For compound 4 the middle estimate is 5.7-fold (0.76 log units) below the measured one; measured number outside the range, above it.
By their numbers in this assay, from the lowest: compound 2; then compounds 1 and 3 (each within the scatter of the next); then compound 4.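

In this assay, within the data shown here, the three earlier groups at this aromatic carbon next to the ring nitrogen stay within a narrow span, whereas (3-(pyrrolidin-1-yl)propyl)sulfanyl moves well outside it, with a 19-fold higher number from compound 2 to compound 4 (1.28 log units; beyond the scatter) as the only large step in the set, alongside a 6.8-fold higher number from compound 1 to compound 4 (0.84 log units; beyond the scatter) and a 6.8-fold higher number from compound 3 to compound 4 (0.84 log units; beyond the scatter). Among these compounds, the position therefore does not accept every substituent equally, and compound 4 is the one member of the four that goes against the narrow span. This single change replaces the linking atom, the ring and the chain together, and nothing measured here accounts for the higher number.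

Which of the sulfur link, the propyl chain or the terminal pyrrolidine carries the step stays open. A (3-(pyrrolidin-1-yl)propyl)amino group or a plain propylsulfanyl group on the same core would separate these parts.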